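The compounds below may be only part of what the source reports. "The series", "measured", "known", "first", "only" and "open" are said of these compounds alone.

Among the compounds with values here, compound 2 `Cc1cc(C)c(CN2CCc3c(Cl)cc([C@H](C)CO)c(Cl)c3C2=O)c(=O)[nH]1` is the better-anchored of the measured pair here: in an ADME assay on microsomes from liver (Homo sapiens) for metabolic stability, read by LC-MS, using NADPH, with stated times of 10 min and 45 min, tested at 1 uM (a lower number here means slower removal, a higher number faster removal of the compound), compound 2 gives 15.8 uL/min, the only number it shows, with one further entry that reports no single number. Compound 1 `COC(c1cc(Cl)c2c(c1Cl)C(=O)N(Cc1c(C)cc(C)[nH]c1=O)CC2)C1CCOC1`, a related structure, has been run repeatedly in this assay, as its entries show (the several entries of compound 1 in this assay, 136 uL/min; 93.3 uL/min; 128 uL/min; 108 uL/min (4 entries)); compound 1 gives 136 uL/min; 93.3 uL/min; 128 uL/min; 108 uL/min (4 entries). Compound 3 `Cc1cc(C)c(CN2CCc3c(Cl)cc([C@@H](CO)[C@@H]4CCCO4)c(Cl)c3C2=O)c(=O)[nH]1` has not yet been measured in this assay. It differs from compound 2 by oxolan-2-yl in place of methyl on a saturated chain carbon bound to an aromatic carbon and a saturated chain carbon. Within the data shown here, no measured pair covers this exact change, so its size cannot be read off directly. Because compound 1, which also carries an oxolanyl, gives 136 uL/min; 93.3 uL/min; 128 uL/min; 108 uL/min (4 entries), compound 3 is expected to be removed faster than compound 2, and the step of a 2.5-fold higher number from compound 2 to compound 3 (0.40 log units; beyond the scatter) is expected to lie beyond the usual scatter. Compound 3 is therefore estimated at 40 uL/min, within a range of 15 uL/min to 110 uL/min.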

Compound 3, intrinsic clearance in a liver preparation (reported as CLH), per the amount of preparation that the assay uses in the liver assay: 70.3 uL/min
The estimate for compound 3 lay 1.8-fold (0.24 log units) below the measured number; measured number inside the range.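

Within the data shown here, in the liver assay, oxolan-2-yl in place of methyl on a saturated chain carbon bound to an aromatic carbon and a saturated chain carbon gives a 4.4-fold higher number from compound 2 to compound 3 (0.65 log units; beyond the scatter), the first direct reading of a change at this position. The same change also moves a second read-out: in a physicochemical assay for solubility, measured as kinetic solubility (a higher number here means a more soluble compound, a lower number a less soluble compound), compound 2 gives 131000 nM and compound 3 gives 550000 nM. Compound 3 therefore has the higher number in both assays, so in this one pair faster removal and higher solubility come together.

A single pair cannot show whether the step follows from the ring, its oxygen or its defined stereocentre. On these data alone, how a cyclopentyl ring, a methoxymethyl group or a simple ethyl group at this place would behave in the liver assay remains open.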